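Swapping a Halopyridine on the Sulfonamide Nitrogen

A few compounds are considered here, and "the series" means these few. Any claim that something is new, unique, unknown or untested is made for them only; others in the source may bear on it.

Measured so far:
compound 1 `O=S(=O)(CSc1nnc(Br)n1Cc1ccc(Br)c2ccccc12)Nc1ccc(Cl)nc1`: 1940 nM
compound 2 `O=S(=O)(CSc1nnc(Br)n1Cc1ccc(Br)c2ccccc12)Nc1cnccc1I`: 10600 nM

Both compounds share one core and differ only in the halopyridine attached to the sulfonamide nitrogen, and both were tested in an assay on HEK293 cells for inhibition of solute carrier family 22 member 12 (Homo sapiens); a lower number here means a stronger inhibitor, a higher number a weaker inhibitor. Within the data shown here, compound 2 has the highest of the two numbers; the only measured step, a 5.5-fold higher number from compound 1 to compound 2 (0.74 log units; beyond the scatter), separates it from compound 1, which is its nearest neighbour.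

Compound 3 `O=S(=O)(CSc1nnc(Br)n1Cc1ccc(Br)c2ccccc12)Nc1ccc(Br)nc1` differs from compound 2 by 6-bromopyridin-3-yl in place of 4-iodopyridin-3-yl on a sulfonamide nitrogen. The group that enters matches the 6-chloropyridin-3-yl of compound 1 except that bromine replaces chlorine, so compound 3 is structurally much closer to compound 1 than to compound 2. Among the measured compounds shown here, the one step that bears on this, a 5.5-fold higher number from compound 1 to compound 2 (0.74 log units; beyond the scatter), ran upward when the halogen moved from the 6- to the 4-position; reversing that pattern suggests a drop of similar size, though only one pair supports it.

Compound 3 is therefore expected to give about 2500 nM, within 1000 nM to 6500 nM. The expected step is a 4.2-fold lower number from compound 2 to compound 3 (0.63 log units; beyond the scatter), towards a lower number.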

Compound 3, half-maximal inhibitory concentration: 2200 nM
Compound 3: the middle estimate sits 1.1-fold (0.06 log units) above what was measured; the measured number falls inside the stated range.
By their numbers in this assay, from the lowest: compounds 1 and 3 (each within the scatter of the next); then compound 2.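

In this assay, the step of a 1.1-fold higher number from compound 1 to compound 3 (0.05 log units; within the scatter) comes from bromo in place of chloro on an aromatic carbon and stays within the scatter, so these two halogens cannot be told apart here. The step of a 4.8-fold lower number from compound 2 to compound 3 (0.68 log units; beyond the scatter) runs the same way as the earlier comparison with compound 1, so the high number of compound 2 is not tied to chlorine alone: 6-chloropyridin-3-yl and 6-bromopyridin-3-yl both stand clear of 4-iodopyridin-3-yl. Nothing measured here explains these differences.

What remains unsettled is whether the iodine itself or its place on the pyridine ring matters more, since both change together in compound 2. A pyridine carrying iodine where 6-bromopyridin-3-yl carries bromine would separate the two, and a methyl group or a nitrile there would test whether a halogen is needed at all.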